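Removing a methyl from the aryl ether of compound 2

The source may report more compounds than this note shows. Statements on the series, on what has been measured and on what is new or still open speak of the compounds shown alone.

Measured so far:
compound 1 `O=C(Nc1cccc(-n2cc(-c3ccncc3)c(-c3ccc(Cl)c(O)c3)n2)c1)Nc1cccc(C(F)(F)F)c1`: 10800 nM
compound 2 `COc1cc(-c2nn(-c3cccc(NC(=O)Nc4cc(C(F)(F)F)cc(C(F)(F)F)c4)c3)cc2-c2ccncc2)ccc1Cl`: 2550 nM

In a functional assay on M14 cells (Homo sapiens) for inhibition, read by sulforhodamine B assay, with a stated time of 48 h (on this read-out higher numbers stand for weaker inhibition of growth and lower numbers for stronger inhibition of growth), compound 2 gives 2550 nM, the lower of the two numbers; the gap to compound 1, which gives 10800 nM, lies beyond the usual scatter. The next compound, compound 3 `O=C(Nc1cccc(-n2cc(-c3ccncc3)c(-c3ccc(Cl)c(O)c3)n2)c1)Nc1cc(C(F)(F)F)cc(C(F)(F)F)c1`, keeps everything else of compound 2 and changes one point: hydrogen in place of methyl on an oxygen on an aromatic ring. This turns the 4-chloro-3-methoxyphenyl group into the 4-chloro-3-hydroxyphenyl group that compound 1 also carries, so compound 3 sits between the two measured compounds in its make-up. Within the data shown here, no measured pair shows this change on its own, so its direction in this assay is open. A step of modest size in either direction is expected, most likely leaving compound 3 near compound 2 with some drift towards weaker inhibition, a step from compound 2 to compound 3 of a 1.6-fold higher number from compound 2 to compound 3 (0.20 log units; within the scatter). Compound 3 is estimated at 4000 nM, in the range 1500 nM to 12000 nM.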

Compound 3, concentration for total growth inhibition: 1810 nM
Estimate against measurement, compound 3: 2.2-fold (0.34 log units) above; the measured number falls inside the stated range.
By their numbers in this assay, from the lowest: compounds 3 and 2 (each within the scatter of the next); then compound 1.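

In this assay, the methoxy group of compound 2 and the hydroxy group of compound 3 cannot be told apart, with a 1.4-fold lower number from compound 2 to compound 3 (0.15 log units; within the scatter) for hydrogen in place of methyl on an oxygen on an aromatic ring. The clear gap instead follows the other change, with a 6.0-fold lower number from compound 1 to compound 3 (0.78 log units; beyond the scatter) for trifluoromethyl in place of hydrogen on an aromatic carbon, so the ether and the second trifluoromethyl group can now be read apart. Nothing in the data gives a reason for either step.

As far as these compounds go, whether a longer chain on this oxygen, such as ethyl, or an amine in place of the hydroxy group would stay in the same range remains open. So does whether methyl and hydrogen on this oxygen would also match on the core of compound 1, which carries only one trifluoromethyl group.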